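The compounds below may be only part of what the source reports. "The series", "measured", "known", "first", "only" and "open" are said of these compounds alone.

Measured compounds:
- compound 1 `Cc1ccc(CS/C(=C/c2c[nH]c3ccc(Cl)cc23)C(=O)c2ccc(Cl)cc2)cc1`: 1000 nM
- compound 2 `Cc1ccc(CS/C(=C/c2c[nH]c3ccc(Br)cc23)C(=O)c2ccc(Cl)cc2)cc1`: 1000 nM

In a functional assay on DU-145 cells (Homo sapiens) for inhibition, read by trypan blue exclusion, with a stated time of 96 h (a lower number here means a stronger inhibitor of growth, a higher number a weaker inhibitor of growth), compound 1 gives 1000 nM, and compound 2 gives 1000 nM. Among the measured compounds shown here, the one measured step, no change at the digits printed from compound 1 to compound 2 (within the scatter), is a bromo in place of chloro on an aromatic carbon. Compound 1 therefore stands level with compound 2 at the digits shown, with no ordering between the two.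

Compound 3 `Cc1ccc(S/C(=C/c2c[nH]c3ccc(Cl)cc23)C(=O)c2ccc(Cl)cc2)cc1` is not yet measured. It differs from compound 1 by 4-methylphenyl in place of 4-methylbenzyl on a sulfur. For the measured compounds named here, the measured step from compound 1 to compound 2 concerns the halogen on the aromatic carbon and does not touch the sulfur, so no measured step bears directly on this change. Going by the values given here, the series so far shows only that the single altered place left the read-out unchanged within the scatter. With no contrary evidence, the step from compound 1 to compound 3 is expected to stay within the scatter, as no change at the digits printed from compound 1 to compound 3 (within the scatter). Compound 3 is estimated at 1000 nM, with a range from 300 nM to 3000 nM.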

Compound 3, concentration for 50% growth inhibition: 1000 nM
For compound 3 middle estimate and measured number coincide at the digits printed, within the range that was stated.
By their numbers in this assay, from the lowest: compounds 1, 2 and 3 (each within the scatter of the next).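

In this assay, the change to 4-methylphenyl in place of 4-methylbenzyl on a sulfur gives no change at the digits printed from compound 1 to compound 3 (within the scatter), so the read-out extends from the halogen on the aromatic carbon to a second place in the series. The sulfur substituent can therefore lose the 4-methylbenzyl group in favour of 4-methylphenyl with no difference seen at the digits printed, though both groups keep one six-membered aromatic ring of carbon only. No independent measurement accompanies this result that could account for it.

Still open, going by these compounds, is how this assay responds to a sulfur substituent without that ring, such as a longer alkyl chain, an amine or a carboxylic acid. Also open, on these data alone, is whether bromo and 4-methylphenyl together on the shared core give the same reading.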